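Aryl amide exchange on a shared core, compound 2 to compound 3

This account rests on a few compounds, and the source may have more. Where it says the series, first, only, none or still open, it means among the compounds named here.

Compound 1 `NC(=O)c1ccc(NC(=O)c2cn(Cc3c(F)cccc3Cl)c3ccc(=O)[nH]c3c2=O)cc1` and compound 2 `NS(=O)(=O)c1ccc(NC(=O)c2cn(Cc3c(F)cccc3Cl)c3ccc(=O)[nH]c3c2=O)cc1` share one core and differ only in the group on the aromatic carbon of the aryl amide. In an in vitro assay on Sf21 cells for inhibition of high affinity 3',5'-cyclic-AMP phosphodiesterase 7A (Homo sapiens), read by scintillation proximity assay, with a stated time of 30 min (a lower number here means a stronger inhibitor, a higher number a weaker inhibitor), compound 1 gives 10 nM and compound 2 gives 20 nM. For the measured compounds named here, the only measured step, a 2.0-fold higher number from compound 1 to compound 2 (0.30 log units; within the scatter), leaves compound 2 holding the higher of the two numbers, with compound 1 nearest and the gap within the scatter.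

Compound 3 `COc1ccc(NC(=O)c2cn(Cc3c(F)cccc3Cl)c3ccc(=O)[nH]c3c2=O)cc1Cl` is not yet measured. The change from compound 2 is 3-chloro-4-methoxyphenyl in place of 4-sulfamoylphenyl on an amide-type nitrogen. Going by the values given here, only the step from compound 1 to compound 2 bears on it, and that step, an exchange of one group on the aryl amide for another, stayed within the scatter. Among the compounds with values here, no measured step covers loss of the hydrogen-bond donor or entry of the chlorine. A modest step in this assay is expected, a 2.0-fold higher number from compound 2 to compound 3 (0.30 log units; within the scatter), leaning toward a higher number but not securely beyond the scatter. Compound 3 is estimated at 40 nM, with a range of 10 nM to 160 nM.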

Compound 3, half-maximal inhibitory concentration: 34 nM
The estimate for compound 3 lay 1.2-fold (0.07 log units) above the measured number; low and high end bracket the measured number.
By their numbers in this assay, from the lowest: compounds 1, 2 and 3 (each within the scatter of the next, the first and the last beyond it).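

In this assay, the exchange of 4-sulfamoylphenyl for 3-chloro-4-methoxyphenyl on the amide-type nitrogen gives a 1.7-fold higher number from compound 2 to compound 3 (0.23 log units; within the scatter), so the group at this position can carry 0 hydrogen-bond donors and still stay within the scatter of compound 2. For the compounds shown here, measured against 4-carbamoylphenyl, the same entering group gives a 3.4-fold higher number from compound 1 to compound 3 (0.53 log units; beyond the scatter), the first step beyond the scatter, though only a modest one. Nothing available explains either step.

The chlorine and the methoxy group enter together, so their separate contributions cannot be read from these compounds. Going by these compounds, it remains open whether a phenyl ring bearing an amine or a carboxylic acid, or a saturated cyclohexyl ring in place of the phenyl ring, would keep the number in this range.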